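Aryl ether variation on the shared macrolide core

The compounds below may be only part of what the source reports. "The series", "measured", "known", "first", "only" and "open" are said of these compounds alone.

Three compounds of the series carry measured numbers. Compound 1 `CC[C@@H]1/C=C(\C)C[C@H](C)C[C@H](OC)[C@H]2O[C@@](O)(C(=O)C(=O)N3CCCC[C@H]3C(=O)O[C@H](/C(C)=C/[C@@H]3CC[C@@H](Oc4ccc(F)cc4)[C@H](OC)C3)[C@H](C)[C@@H](O)CC1=O)[C@H](C)C[C@@H]2OC` gives 3.4 nM in a functional assay on cells for inhibition, with Murine T-cell line (Mus musculus) as the target; on this read-out higher numbers stand for weaker inhibition and lower numbers for stronger inhibition. Compound 2 `CC[C@@H]1/C=C(\C)C[C@H](C)C[C@H](OC)[C@H]2O[C@@](O)(C(=O)C(=O)N3CCCC[C@H]3C(=O)O[C@H](/C(C)=C/[C@@H]3CC[C@@H](Oc4ccc(C)cc4)[C@H](O)C3)[C@H](C)[C@@H](O)CC1=O)[C@H](C)C[C@@H]2OC` gives 6 nM in this assay, a value within the scatter of that of compound 1. Compound 3 `CC[C@@H]1/C=C(\C)C[C@H](C)C[C@H](OC)[C@H]2O[C@@](O)(C(=O)C(=O)N3CCCC[C@H]3C(=O)O[C@H](/C(C)=C/[C@@H]3CC[C@@H](O)[C@H](Oc4ccc(O)cc4)C3)[C@H](C)[C@@H](O)CC1=O)[C@H](C)C[C@@H]2OC` gives 0.9 nM in this assay, and this number stands beyond the scatter below that of compound 1, so compound 1 holds the second highest of the three numbers, with compound 2 nearest and compound 3 furthest.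

Compound 4 `CC[C@@H]1/C=C(\C)C[C@H](C)C[C@H](OC)[C@H]2O[C@@](O)(C(=O)C(=O)N3CCCC[C@H]3C(=O)O[C@H](/C(C)=C/[C@@H]3CC[C@@H](Oc4ccc(N(C)C)cc4)[C@H](OC)C3)[C@H](C)[C@@H](O)CC1=O)[C@H](C)C[C@@H]2OC` keeps the core of compound 1 and differs from it in one place: dimethylamino in place of fluoro on an aromatic carbon. The change sits on an aromatic carbon of a six-membered aromatic ring of carbon only, on the aryl ether that also varies among compounds 1, 2 and 3. Among the measured compounds shown here, no measured pair shows this substitution, so no step for it is known.

The values of compounds 1 and 2 differ little although their aryl ethers differ, so for the step to compound 4 no change beyond the scatter is expected, a 1.2-fold higher number from compound 1 to compound 4 (0.07 log units; within the scatter). Compound 4 is therefore estimated at 4 nM, within a range from 1.5 nM to 12 nM.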

Compound 4, half-maximal inhibitory concentration: 1.1 nM
Beside the measured number, compound 4's estimate is 3.6-fold (0.56 log units) above it, and the stated range ends above it.
By their numbers in this assay, from the lowest: compounds 3 and 4 (each within the scatter of the next); then compounds 1 and 2 (each within the scatter of the next).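

In this assay, among the compounds shown here, the change from 4-fluorophenoxy to 4-(dimethylamino)phenoxy gives the first step with only one point of difference, and the step of a 3.1-fold lower number from compound 1 to compound 4 (0.49 log units; beyond the scatter) is modest but lies beyond the scatter. The aromatic carbon para to a large group therefore responds to the group it carries, which compounds 1 and 2 could not show, as they differ in more than one place. Nothing measured here accounts for this step.

From the compounds shown here alone, whether other groups on this carbon, such as an amino group, a methoxy group or a carboxylic acid, would move the number in the same way remains open. Also open, going by these compounds, is whether the same change would give a similar step on the core of compound 2, which carries a hydroxyl where compound 1 carries a methoxy.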